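Swapping the ring-nitrogen side chain in a shared core

The source may report more compounds than this note shows. Statements on the series, on what has been measured and on what is new or still open speak of the compounds shown alone.

Measured compounds:
- compound 1, `Cc1ccc(NC(=O)c2ccc(Cl)c(C(F)(F)F)c2)cc1C#Cc1nn(C[C@@H](C)CO)c2ncnc(N)c12`: 319 nM
- compound 2, `Cc1ccc(NC(=O)c2ccc(Cl)c(C(F)(F)F)c2)cc1C#Cc1nn(C[C@H](C)CO)c2ncnc(N)c12`: 323 nM

Both compounds were tested in a functional assay on MDA-MB-435 cells (Homo sapiens) for antiproliferative activity, read by MTT assay, with a stated time of 72 h; a higher number here means a weaker inhibitor, a lower number a stronger inhibitor. Compound 1 gives 319 nM there, and compound 2 gives 323 nM. For the measured compounds named here, the one measured step, a 1.0-fold higher number from compound 1 to compound 2 (0.01 log units; within the scatter), concerns a pair that differs only in the configuration as drawn at one stereocentre (the fact that compounds 1 and 2 differ only in the configuration as drawn); the two values sit within the scatter of each other, so no order between compound 1 and compound 2 can be claimed. Going by the values given here, compound 2 therefore stands beside compound 1, with no other measured compound for comparison.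

Compound 3, `Cc1ccc(NC(=O)c2ccc(Cl)c(C(F)(F)F)c2)cc1C#Cc1nn([C@H]2CC[C@H](O)CC2)c2ncnc(N)c12`, is not yet measured. Its change from compound 2 is 4-hydroxycyclohexyl in place of 2-(hydroxymethyl)propyl on an aromatic nitrogen. Among the compounds with values here, no measured step concerns this kind of exchange; the only step available, the one from compound 1 to compound 2, changes configuration alone and does not address a different group on the aromatic nitrogen. With no direct evidence, compound 3 is expected to land near compound 2, the step of a 1.0-fold lower number from compound 2 to compound 3 (0.00 log units; within the scatter) being small in either direction, with a wide range. The estimate for compound 3 in this assay is 320 nM, from 90 nM to 1200 nM.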

Compound 3, half-maximal inhibitory concentration: 37 nM
Compound 3: middle estimate off by 8.6-fold (0.94 log units), on the high side; the whole stated range lies above it.
By their numbers in this assay, from the lowest: compound 3; then compounds 1 and 2 (each within the scatter of the next).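

In this assay, the group on the aromatic nitrogen proves to matter: 4-hydroxycyclohexyl in place of 2-(hydroxymethyl)propyl gives an 8.7-fold lower number from compound 2 to compound 3 (0.94 log units; beyond the scatter), and the same exchange gives an 8.6-fold lower number from compound 1 to compound 3 (0.94 log units; beyond the scatter). The earlier pair showed only that reversing one stereocentre in the chain leaves the number within the scatter, and the exchange now gives a step of the same size from either form of that chain: the fact that compounds 1 and 2 differ only in the configuration as drawn. The two groups have the same counts of hydrogen-bond donors and acceptors and no net charge, so the step goes with a change those counts do not capture, while the entering group brings a six-membered carbon ring and a larger heavy-atom count together, and this single exchange cannot separate the two.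

From the compounds shown here alone, what remains open is which of these features goes with the step, and whether the hydroxyl group takes part in it at all. A plain cyclohexyl group, a 4-aminocyclohexyl group, the other stereoisomer of 4-hydroxycyclohexyl or a longer open chain ending in a hydroxyl group would each test a different part of that question.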